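Swapping trifluoromethyl for fluoro on a benzyl group

A few compounds are considered here, and "the series" means these few. Any claim that something is new, unique, unknown or untested is made for them only; others in the source may bear on it.

Measured compounds and their values in an assay on isolated protein for binding affinity to adenosine receptor A1 (Bos taurus); a higher number here means a weaker inhibitor, a lower number a stronger inhibitor:
compound 1 `COc1ccc(C(=O)Nc2nc(-c3ccccc3)nc3c2nnn3Cc2ccccc2F)cc1`: 21900000 nM
compound 2 `FC(F)(F)c1ccccc1Cn1nnc2c(NC3CCCC3)nc(-c3ccccc3)nc21`: 600000 nM
compound 3 `FC(F)(F)c1ccccc1Cn1nnc2c(NC3CCCCC3)nc(-c3ccccc3)nc21`: 6800000 nM

Compound 3 stands second highest of the three numbers in this assay; compound 1 sits nearest to it with a higher number, and compound 2 furthest with a lower one. Within the data shown here, the one step known in this set, an 11-fold higher number from compound 2 to compound 3 (1.05 log units; beyond the scatter), exchanges the ring on the nitrogen and says nothing about the benzyl substituent.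

Compound 4 `Fc1ccccc1Cn1nnc2c(NC3CCCCC3)nc(-c3ccccc3)nc21` differs from compound 3 in that change: fluoro in place of trifluoromethyl on an aromatic carbon. Compound 1 also carries a 2-fluorobenzyl group, but it differs from compound 3 at the amine as well. The value of compound 1, 21900000 nM, therefore cannot be read as a test of this change alone. Among the measured compounds shown here, no measured step bears directly on fluoro in place of trifluoromethyl here. Without such a precedent, compound 4 is expected to stay near compound 3, with a step of a 1.1-fold lower number from compound 3 to compound 4 (0.05 log units; within the scatter) that is expected to fall within the scatter. The estimate for compound 4 in this assay is 6000000 nM, within a range from 1500000 nM to 25000000 nM.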

Compound 4, inhibition constant: 1150000 nM
Compound 4: middle estimate off by 5.2-fold (0.72 log units), on the high side; the whole stated range lies above it.
By their numbers in this assay, from the lowest: compounds 2 and 4 (each within the scatter of the next); then compound 3; then compound 1.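

In this assay, among these compounds, the benzyl substituent proves to be a position that moves the number: with the cyclohexyl group on the nitrogen held constant, fluoro in place of trifluoromethyl on the aromatic carbon gives a 5.9-fold lower number from compound 3 to compound 4 (0.77 log units; beyond the scatter), the only direct reading of this change in the set. The 2-fluorobenzyl group also allows a second single-place comparison, in which cyclohexyl in place of (4-methoxyphenyl)carbonyl on the nitrogen gives a 19-fold lower number from compound 1 to compound 4 (1.28 log units; beyond the scatter), so the group on the nitrogen matters with this benzyl group as well as with the 2-(trifluoromethyl)benzyl group. There is no measurement here that accounts for either step.

Whether fluoro in place of trifluoromethyl gives a similar step with a cyclopentyl group on the nitrogen remains open, as compound 2 is the only cyclopentyl compound shown and it carries the 2-(trifluoromethyl)benzyl group. Also open, going by these compounds, is how chloro, methoxy or a plain hydrogen on that same aromatic carbon would compare with fluoro and trifluoromethyl.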